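Acetylated and free sugar amides: the isopropyl step

This account rests on a few compounds, and the source may have more. Where it says the series, first, only, none or still open, it means among the compounds named here.

Three compounds have been run in a functional assay on the whole organism (Ear, strain ICR) for inhibition, with Mus musculus as the target, with stated times of 30 min and 2 h, at a dose of 10 umol/kg by the oral route; on this read-out higher numbers stand for more inhibition at the one dose given (going by the name of the read-out) and lower numbers for less inhibition. Compound 1 `CC(=O)OC[C@H]1O[C@H](OC(C)=O)[C@H](NC(=O)[C@H](C)NCCC2OCC(C)(C)CO2)[C@@H](OC(C)=O)[C@@H]1OC(C)=O` gives 84.2%. Compound 2 `CC(=O)OC[C@H]1O[C@H](OC(C)=O)[C@H](NC(=O)[C@H](CC(C)C)NCCC2OCC(C)(C)CO2)[C@@H](OC(C)=O)[C@@H]1OC(C)=O` gives 86.6%; it differs from compound 1 by isopropyl in place of hydrogen on a saturated chain carbon, two bonds along the chain from an amine nitrogen and a carbonyl carbon, and the step is a number 2.4 percentage points higher from compound 1 to compound 2 (within the scatter). Compound 3 `C[C@H](NCCC1OCC(C)(C)CO1)C(=O)N[C@H]1C(O)O[C@H](CO)[C@@H](O)[C@@H]1O` gives 86.8%; this number and those of compounds 1 and 2 all lie within the scatter of one another, so no order is claimed among the three. The difference between the core of compound 1 and the core of compound 3 is not broken down here.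

Compound 4 `CC(C)C[C@H](NCCC1OCC(C)(C)CO1)C(=O)N[C@H]1C(O)O[C@H](CO)[C@@H](O)[C@@H]1O` is not yet measured in this assay. For the measured compounds named here, it differs from compound 3 by isopropyl in place of hydrogen on a saturated chain carbon, two bonds along the chain from an amine nitrogen and a carbonyl carbon, the same change as the one from compound 1 to compound 2, at a place described in the same words. Because the earlier step was a number 2.4 percentage points higher from compound 1 to compound 2 (within the scatter) and because compound 3 gives 86.8%, compound 4 is expected to give 89%. The expected step of a number 2.2 percentage points higher from compound 3 to compound 4 (within the scatter) is thus estimated to stay within the scatter, with the estimate for compound 4 running from 80% to 96%.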

Compound 4, a percentage reported as inhibition, in the whole organism at one dose (the size of the read-out at that dose, not a potency): 81.8%
For compound 4 the middle estimate is 7.2 percentage points above the measured one; low and high end bracket the measured number.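

In this assay, for the compounds shown here, isopropyl in place of hydrogen on the core of compound 3 gives a number 5 percentage points lower from compound 3 to compound 4 (within the scatter), so on this core the change produces no step that can be told from repeat measurement. Set beside the same change on the core of compound 1, the step does not differ in a way the data can resolve: the same change on two cores in this assay, a number 2.4 percentage points higher (within the scatter) from compound 1 to compound 2 and a number 5 percentage points lower (within the scatter) from compound 3 to compound 4, 7.4 percentage points apart, within the scatter of two such steps. This is compatible with the change carrying over between the two cores with little effect on the read-out, but with one pair per core it does not show that the step is the same on both, and the opposite directions of the two steps cannot be read as a reversal.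

The compounds shown leave open whether another group on this saturated chain carbon, such as a longer chain, an amine or a carboxylic acid, would give a step beyond the scatter on either core. Also open, on these data alone, is how these steps would read at any dose other than the one given.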